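Oxazole ketone inhibitors: replacing the pyridyl with a dimethylcarbamoyl

A few compounds are considered here, and "the series" means these few. Any claim that something is new, unique, unknown or untested is made for them only; others in the source may bear on it.

Measured compounds:
compound 1 `O=C(CCCCCCc1ccccc1)c1nc(-c2ccccn2)co1` 1.9 nM
compound 2 `O=C(CCCCCCc1ccccc1)c1nc(-c2ccncc2)co1` 1.6 nM

Compound 2 and compound 1 share a core that carries a seven-carbon chain ending in a phenyl ring and differ only in the ring attached to the oxazole. For the measured compounds named here, in an assay on isolated protein for inhibition of Fatty-acid amide hydrolase 1 (Rattus norvegicus) (a higher number here means a weaker inhibitor, a lower number a stronger inhibitor), compound 2 gives 1.6 nM, the lower of the two numbers, with compound 1 as the only neighbour: a 1.2-fold lower number from compound 1 to compound 2 (0.07 log units; within the scatter). The two values therefore cannot be told apart.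

Compound 3 `CN(C)C(=O)c1coc(C(=O)CCCCCCc2ccccc2)n1` carries the change (dimethylcarbamoyl in place of pyridin-4-yl on an aromatic carbon). Going by the values given here, none of the measured steps bears on this change: the only step known swaps one pyridyl ring for another, and it stays within the scatter. Nothing in the data shows what happens when the aromatic ring is given up for an acyclic amide, so the expectation for compound 3 in this assay must rest on the change itself and is wide. Compound 3 is estimated at 15 nM, with a range of 3 nM to 80 nM, which means an expected step of a 9.4-fold higher number from compound 2 to compound 3 (0.97 log units; beyond the scatter), a loss that may well exceed the scatter.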

Compound 3, inhibition constant: 35 nM
Estimate against measurement, compound 3: 2.3-fold (0.37 log units) below; the range from low to high includes it.
By their numbers in this assay, from the lowest: compounds 2 and 1 (each within the scatter of the next); then compound 3.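

In this assay, for the compounds shown here, this position, on an aromatic carbon next to the ring nitrogen, had so far held only two pyridyl rings that could not be told apart. Dimethylcarbamoyl, which has no ring, is the first group here to move the number beyond the scatter, with a 22-fold higher number from compound 2 to compound 3 (1.34 log units; beyond the scatter) and an 18-fold higher number from compound 1 to compound 3 (1.27 log units; beyond the scatter). Both steps are large, so the position is not indifferent to what it carries, even though the pyridin-2-yl and pyridin-4-yl groups match each other and the groups exchanged have the same counts of hydrogen-bond donors and acceptors; nothing available accounts for the loss.

The compounds shown leave open whether the loss follows from giving up the aromatic ring or from the amide itself, a question that a phenyl ring, a methyl ester or an unsubstituted carboxamide at this place would bear on. They also leave open whether a ring-containing amide such as a pyrrolidine-1-carbonyl group would behave like dimethylcarbamoyl, and whether the same step would hold with a shorter chain on the shared core.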